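The compounds below may be only part of what the source reports. "The series", "measured", "known", "first", "only" and "open" are said of these compounds alone.

Compound 2 `C=C1C[C@]23C[C@@]1(O)CC[C@H]2c1ccc(OS(=O)(=O)c2ccc(C)cc2)c(C)c1[C@@H]3Cn1cc(-c2ccc(Br)cc2)nn1` shares its core with compound 1 `C=C1C(=O)[C@]23C[C@@]1(O)CC[C@H]2c1ccc(OS(=O)(=O)c2ccc(C)cc2)c(C)c1[C@@H]3Cn1cc(-c2ccc(Br)cc2)nn1` and with compound 3 `C=C1C[C@]23C[C@@]1(O)CC[C@H]2c1ccc(O)c(C)c1[C@@H]3Cn1cc(-c2ccc(Br)cc2)nn1`, all three carrying the same 4-(4-bromophenyl)-1H-1,2,3-triazol-1-yl arm. In a functional assay on SMMC-7721 cells (Homo sapiens) for cytotoxicity, read by MTT assay, with a stated time of 4 days (a higher number here means a weaker inhibitor, a lower number a stronger inhibitor), compound 1 gives 4320 nM. For compound 2 this assay reports only a limit, > 20000 nM, and no number. For compound 3 it likewise reports only a limit, > 20000 nM. For the measured compounds named here, the one step that connects two measured compounds, a step that the two limits leave unreadable from compound 2 to compound 3, cannot be read in size because both of its ends sit at the limit of > 20000 nM in this assay, at which 2 of the 3 values shown sit. Compound 2 therefore stands as a limit alone, without a measured number to anchor it.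

Compound 4 `C=C1C[C@]23C[C@@]1(O)CC[C@H]2c1ccc(OS(=O)(=O)c2ccc(C)cc2)c(C)c1[C@@H]3Cn1cc(-c2ccc(F)cc2)nn1` differs from compound 2 by fluoro in place of bromo on an aromatic carbon. No measured step bears on this change: the only step shown concerns the oxygen on the aromatic ring, not the halogen on the distal phenyl, and it is itself unreadable. With nothing to suggest a gain in potency, compound 4 is expected to remain where compound 2 stands, most likely reported again as a limit. The step that the limit leaves unreadable from compound 2 to compound 4 is thus estimated as none beyond the scatter. Compound 4 is expected at about 25000 nM, within a range from 8000 nM to 80000 nM.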

Compound 4, half-maximal inhibitory concentration: > 20000 nM
Compound 4 gave a limit, no number; the forecaster's own chance of this, stated with the estimate: 70%; the middle value does not contradict the limit.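

Compound 2 and compound 4 are both reported in this assay only as limits, so no step can be read for fluoro in place of bromo, because both ends sit at the same limit: the limit of > 20000 nM in this assay, at which 3 of the 4 values shown sit.

The compounds shown leave open whether this change alters potency at all, including on the core of compound 1.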